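A few compounds are considered here, and "the series" means these few. Any claim that something is new, unique, unknown or untested is made for them only; others in the source may bear on it.

Within the data shown here, compound 3 `Cc1nc(NCCNC(=O)NC(C)(C)C)nc(N[C@@H]2C[C@H](CO)[C@@H](O)[C@H]2O)c1-c1nc2ccccc2s1` is one of three compounds measured in an ADME assay on cells (Homo sapiens) for cytotoxicity, read by polymerase chain reaction, with a stated time of 3 days; on this read-out lower numbers stand for higher toxicity in this test and higher numbers for lower toxicity in this test. For compound 3 the result is a limit, > 25000 nM. Compound 1 `CNc1nc(C)c(-c2nc3ccccc3s2)c(N[C@@H]2C[C@H](CO)[C@@H](O)[C@H]2O)n1` likewise gives only a limit, > 25000 nM. Compound 2 `Cc1nc(NCCOC(C)C)nc(N[C@@H]2C[C@H](CO)[C@@H](O)[C@H]2O)c1-c1nc2ccccc2s1` gives a number, 8000 nM. Compound 3 therefore sits at the limit of > 25000 nM in this assay, at which 2 of the 3 values shown sit, and its step from compound 1 is a step that the two limits leave unreadable from compound 1 to compound 3. Compound 4 `Cc1nc(NCc2cccnc2)nc(N[C@@H]2C[C@H](CO)[C@@H](O)[C@H]2O)c1-c1nc2ccccc2s1` differs from compound 3 by pyridin-3-yl in place of (((tert-butyl)carbamoyl)amino)methyl on a saturated chain carbon bound to a nitrogen on an aromatic ring. Among the measured compounds shown here, no measured step makes this same change; the nearest are an at least 3.1-fold lower number from compound 1 to compound 2 (0.49 log units; beyond the scatter) and an at least 3.1-fold higher number from compound 2 to compound 3 (0.49 log units; beyond the scatter), each beyond the scatter and each moving between the limit and a number. A swap at the chain end is thus expected to move the result only within that span, and compound 4 is estimated at 20000 nM, between 7000 nM and 25000 nM. That expectation corresponds to an at least 1.2-fold lower number from compound 3 to compound 4 (0.09 log units; that floor lies within the scatter).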

Compound 4, half-maximal cytotoxic concentration: 5000 nM
Beside the measured number, compound 4's estimate is 4.0-fold (0.60 log units) above it; measured number below the stated range.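

Pyridin-3-yl on the saturated chain carbon bound to a nitrogen on an aromatic ring gives an at least 5.0-fold lower number from compound 3 to compound 4 (0.69 log units; beyond the scatter), and an at least 5.0-fold lower number from compound 1 to compound 4 (0.69 log units; beyond the scatter). A measurable cytotoxic concentration is thus no longer tied to the isopropoxymethyl group alone, and a group with an aromatic ring also gives one. The isopropoxymethyl and pyridin-3-yl groups cannot be told apart, with a 1.6-fold lower number from compound 2 to compound 4 (0.20 log units; within the scatter).

Still open, as far as these compounds go, is whether a phenyl group, which lacks the ring nitrogen, would give a number like these. A carboxylic acid at this place is equally untested here.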